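Replacing a Piperidine with a Piperazine in a Dopamine Transporter Series

The compounds below may be only part of what the source reports. "The series", "measured", "known", "first", "only" and "open" are said of these compounds alone.

Measured so far:
- compound 1, `Clc1ccccc1Oc1ncccc1C1CCNCC1`, gives 5150 nM in an assay on HEK293 cells for displacement of a labelled ligand from sodium-dependent dopamine transporter (Homo sapiens), read by scintillation proximity assay; a lower number here means a stronger inhibitor, a higher number a weaker inhibitor
- compound 2, `FC(F)(F)c1ccccc1Oc1ncccc1C1CCNCC1`, gives 6650 nM in this assay

Among the compounds with values here, compound 1 has the lower of the two numbers, and its only neighbour is compound 2. Within the data shown here, the single measured step, a 1.3-fold higher number from compound 1 to compound 2 (0.11 log units; within the scatter), is within the scatter, so the two compounds cannot be told apart on potency.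

Compound 3, `Clc1ccccc1Oc1ncccc1N1CCNCC1`, differs from compound 1 in one place: piperazin-1-yl in place of piperidin-4-yl on an aromatic carbon. The piperidine carries its hydrogen-bond donor in the ring, and the piperazine keeps that donor while adding a second ring nitrogen at the point of attachment.

Among the measured compounds shown here, no measured step bears on this change. For the measured compounds named here, the one step available alters the other aromatic ring and is within the scatter, so it says nothing about the saturated ring. The expectation for compound 3 therefore rests on compound 1 alone, with wide uncertainty and no clear direction; a modest drift toward a higher number is taken as the middle guess, giving an expected step of a 1.6-fold higher number from compound 1 to compound 3 (0.19 log units; within the scatter). Compound 3 is estimated at 8000 nM in this assay, expected to fall between 2000 nM and 30000 nM.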

Compound 3, inhibition constant: > 6320 nM
Compound 3 gave a limit, no number (the forecaster's own chance of this, stated with the estimate: 15%); the middle value is on the limit's open side.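

Compound 3 has a limit in this assay and not a number: the limit of > 6320 nM in this assay, at which 1 of the 3 values shown sits.

Within the data shown here, this is the first look at the saturated ring, as the earlier pair differed only on the other aromatic ring, and piperazin-1-yl in place of piperidin-4-yl gives an at least 1.2-fold higher number from compound 1 to compound 3 (0.08 log units; that floor lies within the scatter). The printed floor of that step cannot be told apart from no change at all, and the step has no upper end, so the real difference could be small or large; what the limit does show is that this change does not lower the number for this aromatic-carbon position, and so it brings no gain in potency over compound 1.

Going by these compounds, how far compound 3 really lies past its limit stays open, and so does whether the same change would act alike with the trifluoromethyl group of compound 2 on the other ring. Also open, on these data alone, is how a morpholine ring or a 4-methylpiperazin-1-yl group would read at this same position, and whether either would give a lower number than the piperidin-4-yl of compound 1.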